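The source may hold more compounds than are shown below. What is called first, only, known or untested is meant among the compounds shown, and "the series" means these compounds.

Measured so far in a toxicity assay on HUVEC cells (Homo sapiens) for inhibition; a lower number here means a stronger inhibitor of growth, a higher number a weaker inhibitor of growth:
- compound 1, `COc1cc(OC)cc(N2CCN(C(=O)c3oc(C)nc3-c3cccc(F)c3)CC2)c1`: 0.126 ug/mL
- compound 2, `Cc1nc(-c2ccccc2)c(C(=O)N2CCN(c3ccc(C)c(C)c3)CC2)o1`: 3.52 ug/mL
- compound 3, `Cc1nc(-c2ccccc2)c(C(=O)N2CCN(c3cccc(F)c3)CC2)o1`: 1.05 ug/mL

Compound 3 stands second highest of the three numbers in this assay. Among the compounds with values here, its nearest neighbour is compound 2, which sits higher by the step of a 3.4-fold lower number from compound 2 to compound 3 (0.53 log units; beyond the scatter) read backwards; compound 1 is the furthest from it and lies well lower, beyond the scatter, though no single-change step connects it to compound 3.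

The next compound, compound 4, `Cc1nc(-c2ccccc2)c(C(=O)N2CCN(c3cccc(Cl)c3)CC2)o1`, differs from compound 3 in one place: chloro in place of fluoro on an aromatic carbon. Within the data shown here, the only measured step, a 3.4-fold lower number from compound 2 to compound 3 (0.53 log units; beyond the scatter), concerns the group on the amine nitrogen in a ring but swaps a whole 3,4-dimethylphenyl for a 3-fluorophenyl; it does not bear directly on a chloro for fluoro exchange on the aromatic carbon. Among the measured compounds shown here, no measured pair shows that exchange. The expectation is therefore a step that stays within the usual scatter, with no direction claimed beyond that.

Compound 4 is estimated at 0.85 ug/mL, with a range from 0.35 ug/mL to 2.5 ug/mL, which means an expected step of a 1.2-fold lower number from compound 3 to compound 4 (0.09 log units; within the scatter) in this assay.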

Compound 4, concentration for 50% growth inhibition: 0.463 ug/mL
For compound 4 the middle estimate is 1.8-fold (0.26 log units) above the measured one; measured number inside the range.
By their numbers in this assay, from the lowest: compound 1; then compound 4; then compound 3; then compound 2.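

In this assay, within the data shown here, this is the first measured exchange at this place, on an aromatic carbon meta to a large group, and chloro in place of fluoro gives a 2.3-fold lower number from compound 3 to compound 4 (0.36 log units; beyond the scatter) as a step of its own. Against the 3,4-dimethylphenyl group the 3-chlorophenyl group gives a 7.6-fold lower number from compound 2 to compound 4 (0.88 log units; beyond the scatter) which exceeds a 3.4-fold lower number from compound 2 to compound 3 (0.53 log units; beyond the scatter) and places compound 4 lowest of the three compounds that share the core of compound 2. Nothing available bears on why the number falls with this exchange.

Going by these compounds, whether bromo, methoxy or nitrile at this same place would extend or reverse the fall remains open. Also open, on these data alone, is whether chloro in place of fluoro would give a similar step on the 3,5-dimethoxyphenyl analogue, compound 1, where the only fluoro sits on a different ring.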